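Aryl swap at the distal position: compound 2 to compound 4

The source may hold more compounds than are shown below. What is called first, only, known or untested is meant among the compounds shown, and "the series" means these compounds.

Compound 2 `CCC(C)(C)Cc1c[nH]c(CCc2ccc(-n3ncnn3)cc2)n1` gives 205 nM in an in vitro assay on CHO cells for displacement of a labelled ligand from Bombesin receptor subtype-3 (Homo sapiens), read by scintillation counting, with a stated time of 2 h (a higher number here means a weaker inhibitor, a lower number a stronger inhibitor), the highest of the three numbers to hand. Compound 1 `CCC(C)(C)Cc1c[nH]c(CCc2ccc(-c3ccncc3)cc2)n1` gives 101 nM and compound 3 `CCC(C)(C)Cc1c[nH]c(CCc2ccc(-c3cnccn3)cc2)n1` gives 51 nM in this assay. The steps of a 2.0-fold higher number from compound 1 to compound 2 (0.31 log units; beyond the scatter) and a 4.0-fold lower number from compound 2 to compound 3 (0.60 log units; beyond the scatter) bear on a ring swap at this position, while the step of a 2.0-fold lower number from compound 1 to compound 3 (0.30 log units; within the scatter) stays within the scatter. Compound 4 `CCC(C)(C)Cc1c[nH]c(CCc2ccc(-c3ccccc3C(=O)O)cc2)n1` carries 2-carboxyphenyl in place of 2H-tetrazol-2-yl on an aromatic carbon. Both measured ring swaps leaving the tetrazolyl end moved the number down by modest amounts, so a modest lower number is expected for compound 4 in this assay, the step of a 2.6-fold lower number from compound 2 to compound 4 (0.41 log units; beyond the scatter) being the estimate. The expected value for compound 4 is 80 nM, with a range from 30 nM to 250 nM.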

Compound 4, half-maximal inhibitory concentration: 11 nM
For compound 4 the middle estimate is 7.3-fold (0.86 log units) above the measured one; the whole stated range lies above it.
By their numbers in this assay, from the lowest: compound 4; then compounds 3 and 1 (each within the scatter of the next); then compound 2.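

In this assay the step of a 19-fold lower number from compound 2 to compound 4 (1.27 log units; beyond the scatter) is the largest seen at this position, and a 9.2-fold lower number from compound 1 to compound 4 (0.96 log units; beyond the scatter) and a 4.6-fold lower number from compound 3 to compound 4 (0.67 log units; beyond the scatter) place the 2-carboxyphenyl end clear of all three other rings shown. The position therefore allows a far lower number than pyridin-4-yl, pyrazin-2-yl or 2H-tetrazol-2-yl had shown. No available evidence bears on this gain. Still open, going by these compounds, is whether the gain needs the carboxylic acid or comes with the phenyl ring alone; an unsubstituted phenyl and a methyl ester would separate these.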